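From 4-cyanophenyl to 2-methoxyphenyl on a carbonyl carbon

The compounds below may be only part of what the source reports. "The series", "measured", "known", "first", "only" and "open" are said of these compounds alone.

Compound 1 (`COc1ccc(-c2cnc(NC(=O)CCc3ccccc3)n2C)cc1`): > 100000 nM
Compound 2 (`COc1ccc(-c2cnc(NC(=O)c3ccc(C#N)cc3)n2C)cc1`): > 100000 nM

In a toxicity assay on THP-1 cells (Homo sapiens) for inhibition (a lower number here means that less compound is tolerated, a higher number that more compound is tolerated), compound 2 gives > 100000 nM as a limit and not a number. Compound 3 (`COc1ccc(-c2cnc(NC(=O)c3ccccc3OC)n2C)cc1`) is not yet measured and carries 2-methoxyphenyl in place of 4-cyanophenyl on a carbonyl carbon. Among the measured compounds shown here, the one measured step at that place is a step that the two limits leave unreadable from compound 1 to compound 2 and it offers no size to carry over. With only the limit of > 100000 nM in this assay, at which 2 of the 2 values shown sit, to go on, no step beyond the scatter is expected in this assay in either direction. Compound 3 is estimated at 100000 nM (expected range 50000 nM to 200000 nM). This estimate amounts to an expected step (a number no higher from compound 2 to compound 3 (the limit leaves the size open)).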

Compound 3, half-maximal cytotoxic concentration: > 100000 nM
Compound 3 gave a limit, no number (the forecaster's own chance of this, stated with the estimate: 85%); the middle value lies on the limit itself.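

In this assay, among the compounds shown here, compound 1, compound 2 and compound 3 all give limits, not numbers, so no step among them can be read: the limit of > 100000 nM in this assay, at which 3 of the 3 values shown sit.

The compounds shown leave open how phenethyl, 4-cyanophenyl and 2-methoxyphenyl on the carbonyl carbon compare in size of effect.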